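The source may hold more compounds than are shown below. What is called first, only, known or untested is meant among the compounds shown, and "the series" means these compounds.

Three compounds with the shared core have been run in a functional assay on the whole organism (Tail, strain ICR) with Mus musculus as the target, in the tail flick test, with a stated time of 60 min, at a dose of 25 umol/kg by the oral route; on this read-out lower numbers stand for a weaker effect and higher numbers for a stronger effect at the one dose given. Compound 1 `C[C@@H](O)[C@H](NC(=O)CN(c1nc(Cl)nc2[nH]cnc12)C1CC1)C(=O)O` gives 30.1%, the lowest of the three numbers. Compound 2 `CC[C@H](C)[C@H](NC(=O)CN(c1nc(Cl)nc2[nH]cnc12)C1CC1)C(=O)OCc1ccccc1` gives 40.6%, and compound 3 `CC(C)[C@H](NC(=O)CN(c1nc(Cl)nc2[nH]cnc12)C1CC1)C(=O)OCc1ccccc1` gives 55.5%; both gaps to compound 1 lie beyond the scatter. Among the measured compounds shown here, the single one-place step among them, a number 14.9 percentage points higher from compound 2 to compound 3 (beyond the scatter), concerns the side chain of the benzyl esters. Compound 4 `NCCCC[C@H](NC(=O)CN(c1nc(Cl)nc2[nH]cnc12)C1CC1)C(=O)O` differs from compound 1 by 4-aminobutyl in place of 1-hydroxyethyl on a saturated chain carbon bound to an amide-type nitrogen and a carbonyl carbon. For the measured compounds named here, no measured step touches this exchange; the step from compound 2 to compound 3 shows only that a side-chain change within the ester pair moved this assay modestly. The expectation is therefore a step of a number 4.9 percentage points higher from compound 1 to compound 4 (within the scatter), with no direction the data can support. Compound 4 is estimated at 35%, within a range of 15% to 55%.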

Compound 4, a percentage reported as activity, at one dose (the size of the read-out at that dose, not a potency): 53.8%
For compound 4 the middle estimate is 18.8 percentage points below the measured one; low and high end bracket the measured number.
By their numbers in this assay, from the lowest: compound 1; then compound 2; then compounds 4 and 3 (each within the scatter of the next).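

In this assay, the saturated chain carbon bound to an amide-type nitrogen and a carbonyl carbon also responds to a side-chain exchange with the carboxylic acid free: 4-aminobutyl in place of 1-hydroxyethyl gives a number 23.7 percentage points higher from compound 1 to compound 4 (beyond the scatter). The earlier step, a number 14.9 percentage points higher from compound 2 to compound 3 (beyond the scatter), covered only the benzyl esters and a much smaller exchange.

Whether the step follows the amine or the longer chain stays open, since a plain butyl chain at this place, without the amine, is not among the compounds shown. No evidence bears on what lies behind the step.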